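Amide variation on a shared core: outlook for compound 4

The compounds below may be only part of what the source reports. "The series", "measured", "known", "first", "only" and "open" are said of these compounds alone.

Measured compounds in a functional assay on MIA PaCa-2 cells (Homo sapiens) for inhibition, read by MTT assay, with a stated time of 3 days; a lower number here means a stronger inhibitor, a higher number a weaker inhibitor:
compound 1 `O=C([C@@H]1CCCN(S(=O)(=O)c2ccc(S(=O)(=O)N3CC[C@@H](O)C3)cc2)C1)N1CCC(F)(F)CC1` gives only a limit, > 3000 nM
compound 2 `CCN(CC)S(=O)(=O)c1ccc(S(=O)(=O)N2CCC[C@@H](C(=O)N[C@H]3CCOC3)C2)cc1` gives only a limit, > 10000 nM
compound 3 `CCN(CC)S(=O)(=O)c1ccc(S(=O)(=O)N2CCC[C@@H](C(=O)N3CCC(COC)CC3)C2)cc1` gives only a limit, > 10000 nM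

Compound 3 stands at a limit in this assay and no number is known for it. Among the measured compounds shown here, the same holds for its two neighbours: two of the three values rest at the limit of > 10000 nM in this assay, at which 2 of the 3 values shown sit, and one at the limit of > 3000 nM in this assay, at which 1 of the 3 values shown sits, so no measured step in the set can be read. For the measured compounds named here, the only one-place change among measured compounds, a step that the two limits leave unreadable from compound 2 to compound 3, is left unreadable by the two limits.

Compound 4 `CCN(CC)S(=O)(=O)c1ccc(S(=O)(=O)N2CCC[C@@H](C(=O)N3CCC(F)(F)CC3)C2)cc1` differs from compound 3 in one place: 4,4-difluoropiperidin-1-yl in place of 4-(methoxymethyl)piperidin-1-yl on a carbonyl carbon. The entering group is the same amide substituent that compound 1 carries on a different sulfonamide, and compound 1 also reached only a limit. Nothing in the set shows that any amide variant moves the read-out off the limit, so the step that the limit leaves unreadable from compound 3 to compound 4 is expected to be none beyond the scatter, with a limit as the likely outcome. Compound 4 is therefore estimated at 15000 nM in this assay, within 4000 nM to 60000 nM.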

Compound 4, half-maximal inhibitory concentration: > 10000 nM
Compound 4 was reported as a limit (the forecaster's own chance of this, stated with the estimate: 85%); the middle value does not contradict the limit.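

In this assay compound 4 gives > 10000 nM, which is a limit. Among the compounds shown here, compound 1, compound 2 and compound 3 also stand at limits, so no step to compound 4 can be read. Going by these compounds, whether any amide or sulfonamide variation on the shared core gives a measurable value in this assay remains open.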